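Lengthening the amide end of compound 2

This account rests on a few compounds, and the source may have more. Where it says the series, first, only, none or still open, it means among the compounds named here.

- compound 1 `COc1cc(N(C)CCN(C)C)c(NC(=O)C=C(C)C)cc1Nc1nc2c(c(-c3cn(C)c4ccc(F)cc34)n1)CSCC2`: 902 nM
- compound 2 `C=CC(=O)Nc1cc(Nc2nc3c(c(-c4cn(C)c5ccccc45)n2)CS(=O)(=O)CC3)c(OC)cc1N(C)CCN(C)C`: 8690 nM

In a functional assay on A549 cells (Homo sapiens) for inhibition, read by MTT assay, with a stated time of 72 h (a lower number here means a stronger inhibitor, a higher number a weaker inhibitor), compound 2 gives 8690 nM, the higher of the two numbers. That makes it a weaker inhibitor than compound 1, by a gap beyond the usual scatter. Compound 3 `CC/C=C\C(=O)Nc1cc(Nc2nc3c(c(-c4cn(C)c5ccccc45)n2)CS(=O)(=O)CC3)c(OC)cc1N(C)CCN(C)C` carries but-1-en-1-yl in place of vinyl on a carbonyl carbon. Within the data shown here, no measured pair shows this change alone, since compound 1 and compound 2 differ in more than one place. The estimated step, a 1.2-fold lower number from compound 2 to compound 3 (0.09 log units; within the scatter), is expected to stay within the scatter. Compound 3 is expected to give 7000 nM, with an estimated range of 2500 nM to 20000 nM.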

Compound 3, half-maximal inhibitory concentration: 1350 nM
Estimate against measurement, compound 3: 5.2-fold (0.71 log units) above; the whole stated range lies above it.
By their numbers in this assay, from the lowest: compounds 1 and 3 (each within the scatter of the next); then compound 2.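

At the amide end, in this assay, replacing vinyl with but-1-en-1-yl on the carbonyl carbon gives a 6.4-fold lower number from compound 2 to compound 3 (0.81 log units; beyond the scatter) and so a stronger inhibitor. This shows that the group at this one place can shift the result on its own, while the rest of the molecule stays the same. Nothing available explains why the longer group gives the lower number.

As far as these compounds go, whether a longer chain, or a chain ending in a dimethylamino group, would lower the number further remains open.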